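The compounds below may be only part of what the source reports. "The series", "measured", "known", "first", "only" and "open" are said of these compounds alone.

Compound 1, `C/C(=C\CC/C(C)=C/CC[C@@H]1[C@@]2(C)CCC(=O)C(C)(C)[C@H]2CC[C@@]1(C)O)CC/C=C(\C)C(=O)OCc1cn(-c2cccc(C)c2)nn1`: in a functional assay on SiHa cells (Homo sapiens) for antiproliferative activity, read by MTT assay, with a stated time of 48 h (on this read-out higher numbers stand for weaker inhibition and lower numbers for stronger inhibition), compound 1 gives > 150000 nM, which is a limit of the assay and not a number.
Compound 2, `C/C(=C\CC/C(C)=C/CC[C@@H]1[C@@]2(C)CCC(=O)C(C)(C)[C@H]2CC[C@@]1(C)O)CC/C=C(\C)C(=O)OCc1cn(-c2ccccc2)nn1`: in this assay compound 2 gives 149000 nM.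
Compound 3, `C/C(=C\CC/C(C)=C/CC[C@@H]1[C@@]2(C)CCC(=O)C(C)(C)[C@H]2CC[C@@]1(C)O)CC/C=C(\C)C(=O)OCc1cn(-c2cccc(F)c2)nn1`: in this assay compound 3 gives > 150000 nM, again a limit of the assay and not a number.

Among the compounds with values here, compound 2 is thus the only compound of the three with a number in this assay; the other two sit at the limit of > 150000 nM in this assay, at which 2 of the 3 values shown sit. The measured steps are all on the aromatic ring of the triazole substituent: a number no higher from compound 1 to compound 2 (the limit leaves the size open), a number no lower from compound 2 to compound 3 (the limit leaves the size open) and a step that the two limits leave unreadable from compound 1 to compound 3, none of them readable in size.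

Compound 4, `C/C(=C\CC/C(C)=C/CC[C@@H]1[C@@]2(C)CCC(=O)C(C)(C)[C@H]2CC[C@@]1(C)O)CC/C=C(\C)C(=O)O`, differs from compound 2 at a different place: hydrogen in place of (1-phenyl-1H-1,2,3-triazol-4-yl)methyl on an oxygen next to a carbonyl group. Within the data shown here, no measured step touches this oxygen, so none of the three steps bears on the change, and the series gives no reading of what removing the whole ester group does.

With compound 2 giving 149000 nM, compound 4 is expected to remain in the same weak region, the step of a 1.2-fold lower number from compound 2 to compound 4 (0.09 log units; within the scatter) being expected within scatter. The estimate for compound 4 in this assay is 120000 nM, with a range from 40000 nM to 300000 nM, and a fair chance that only a limit is reported.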

Compound 4, half-maximal inhibitory concentration: 96700 nM
For compound 4 the middle estimate is 1.2-fold (0.09 log units) above the measured one; low and high end bracket the measured number.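

In this assay, within the data shown here, the oxygen next to a carbonyl group gives the first step that can be read with a number at both ends: a 1.5-fold lower number from compound 2 to compound 4 (0.19 log units; within the scatter). Replacing the (1-phenyl-1H-1,2,3-triazol-4-yl)methyl group with hydrogen therefore leaves compound 4 in the same weak region as compound 2, and the two aromatic rings of that group show no measurable contribution to inhibition on this read-out. The steps among compound 1, compound 2 and compound 3 still cannot be read in size, and compound 1 and compound 3 remain limits of the assay and not numbers: the limit of > 150000 nM in this assay, at which 2 of the 4 values shown sit.

Among these compounds, whether any other replacement at this oxygen can move the number beyond the scatter stays open, since only the hydrogen and the one triazole-bearing group can be compared here; a methyl ester, an amide or a longer chain ending in an amine would test this. Also open, on these data alone, is whether a change on the shared core, rather than at this oxygen, can bring the series out of this weak region.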